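From methylsulfanyl to isopropylsulfanyl on a shared core

This account rests on a few compounds, and the source may have more. Where it says the series, first, only, none or still open, it means among the compounds named here.

Of the compounds shown here, three with a shared core have been measured in an ADME assay on CCRF-HSB-2 cells (Homo sapiens) for cytotoxicity, with a stated time of 7 days (on this read-out higher numbers stand for lower toxicity in this test and lower numbers for higher toxicity in this test), and none of them has yet given a number. Compound 3 `CSc1nc(N)nc2c1ncn2/C=C1/CC1(CO)CO` gives > 100000 nM as a limit of the assay and not a number. It therefore stands at the limit of > 100000 nM in this assay, at which 1 of the 3 values shown sits, and has no exact place on the scale. Compound 1 `Nc1nc(N2CCCC2)c2ncn(/C=C3/CC3(CO)CO)c2n1` gives > 20000 nM as a limit too. Compound 2 `Nc1nc(NC2CCCC2)c2ncn(/C=C3/CC3(CO)CO)c2n1` gives > 20000 nM as a limit as well.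

Compound 4 `CC(C)Sc1nc(N)nc2c1ncn2/C=C1/CC1(CO)CO` has isopropyl in place of methyl on a sulfur, counted as isopropyl in place of methyl on a sulfur and leaving the rest of compound 3 unchanged. Within the data shown here, no measured step alters that sulfur substituent. The nearest evidence is a step that the two limits leave unreadable from compound 1 to compound 3 together with a step that the two limits leave unreadable from compound 2 to compound 3 and a step that the two limits leave unreadable from compound 1 to compound 2 so none offers a size or a direction to carry over.

With no measured size to draw on, no step beyond the scatter is expected, and a reading at a limit is the likeliest outcome. The expected change is an at least 1.2-fold lower number from compound 3 to compound 4 (0.09 log units; that floor lies within the scatter) as an estimate with wide uncertainty. Compound 4 is expected near 80000 nM with an estimated range from 20000 nM to 200000 nM in this assay as its read-out.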

Compound 4, half-maximal cytotoxic concentration: 94000 nM
Compound 4: middle estimate off by 1.2-fold (0.07 log units), on the low side; the measured number falls inside the stated range.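

In this assay, compound 4 is the first of the compounds shown whose reading is an exact number and not a limit of the assay, which gives this sulfur substituent a fixed point on the scale for the first time. Isopropyl in place of methyl on a sulfur gives an at least 1.0-fold lower number from compound 3 to compound 4 (0.02 log units; that floor lies within the scatter), so this change has a direction and a floor but no upper size, and that floor leaves open whether the real step is any larger than the usual scatter of the assay. The size stays unknown, as the reading for compound 3 remains a limit of the assay: the limit of > 100000 nM in this assay, at which 1 of the 4 values shown sits.

The steps from compound 1 and from compound 2 to compound 4 cannot be read, and the readings for compound 1 and compound 2 are limits of the assay too: the limit of > 20000 nM in this assay, at which 2 of the 4 values shown sit. What the compounds shown leave open is how the read-out would respond to a longer chain such as n-butyl on the sulfur, to benzyl there, or to a carboxylic acid at the end of that chain, and whether any of these would bring the number down by more than the scatter.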